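Ethyl to fluoro on the benzoyl side

A few compounds are considered here, and "the series" means these few. Any claim that something is new, unique, unknown or untested is made for them only; others in the source may bear on it.

Among the measured compounds shown here, in an ADME assay on MRC5 cells (Homo sapiens) for inhibition, with a stated time of 72 h (on this read-out higher numbers stand for an effect only at larger amounts of compound and lower numbers for an effect already at smaller amounts), compound 1 `CCc1ccccc1C(=O)Nc1c[nH]nc1C(=O)N[C@H]1CC[C@H](OC)CC1` gives 3400 nM as the only actual number. Compound 2 `COc1cccc(OC)c1C(=O)Nc1c[nH]nc1C(=O)NCC1CCCCC1` gives > 50000 nM as a limit of the assay. Compound 3 `COc1cccc(OC)c1C(=O)Nc1c[nH]nc1C(=O)Nc1ccccc1` gives > 50000 nM as a limit too. Compound 4 `CO[C@H]1CC[C@H](NC(=O)c2n[nH]cc2NC(=O)c2ccccc2F)CC1` has fluoro in place of ethyl on an aromatic carbon, ortho to a large group (fluoro in place of ethyl on an aromatic carbon). For the measured compounds named here, the single measured step (a step that the two limits leave unreadable from compound 2 to compound 3) lies at another place, so no measured step covers this change. Given the limit of > 50000 nM in this assay, at which 2 of the 3 values shown sit, as the only other reference, a moderate step toward larger numbers is expected, and the estimate is uncertain (a 2.4-fold higher number from compound 1 to compound 4 (0.37 log units; beyond the scatter)). Compound 4 is expected at 8000 nM (estimated range 2000 nM to 40000 nM).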

Compound 4, half-maximal effective concentration: 1000 nM
Compound 4: middle estimate off by 8.0-fold (0.90 log units), on the high side, outside the stated range (below it).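

On an aromatic carbon, ortho to a large group, fluoro in place of ethyl gives a 3.4-fold lower number from compound 1 to compound 4 (0.53 log units; beyond the scatter) in this assay with the rest of compound 1 unchanged. Among the compounds shown here, the ethyl group is therefore not required for a measurable effect, and this place changes the read-out, which the earlier compounds could not show. Nothing shown gives a cause for this step.

On these data alone, whether chloro, methyl or a longer chain such as propyl at this place would move the read-out further remains open. So does whether the same exchange carries over to other amide groups.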